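Acetyl for Methyl on the Aryl Oxygen of Compound 1

This account rests on a few compounds, and the source may have more. Where it says the series, first, only, none or still open, it means among the compounds named here.

Compound 1 `COc1ccc(-c2cc3c(OC)cc(OC)cc3n(C)c2=O)cc1` was tested in a functional assay on MCF7 cells (Homo sapiens) for cytotoxicity, read by colorimetric assay and MTT assay (a lower number here means a stronger inhibitor, a higher number a weaker inhibitor), where compound 1 gives 10000 nM. Two companions vary only the group on the saturated chain carbon bound to the aromatic nitrogen. Compound 2 `COc1ccc(-c2cc3c(OC)cc(OC)cc3n(CC#N)c2=O)cc1` carries cyano there, and in this assay compound 2 gives 10000 nM. Compound 3 `COC(=O)CCn1c(=O)c(-c2ccc(OC)cc2)cc2c(OC)cc(OC)cc21` carries (methoxycarbonyl)methyl there, and in this assay compound 3 gives 10000 nM. The steps were no change at the digits printed from compound 1 to compound 2 (within the scatter), no change at the digits printed from compound 1 to compound 3 (within the scatter) and no change at the digits printed from compound 2 to compound 3 (within the scatter), so compound 1 stands level with compounds 2 and 3, and none of the three is separated from the others.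

Compound 4 `COc1cc(OC)c2cc(-c3ccc(OC(C)=O)cc3)c(=O)n(C)c2c1` has not yet been measured. It differs from compound 1 in one place: acetyl in place of methyl on an oxygen on an aromatic ring. Among the compounds with values here, none of the measured steps touches this part of the molecule; all three alter the chain on the aromatic nitrogen and leave the oxygen on the aromatic ring untouched, so they offer no direct guide. What they do show is that three variations of the shared core sat at the same level. With nothing pointing either way, for compound 4 the expectation is no step beyond the scatter, no change at the digits printed from compound 1 to compound 4 (within the scatter). Compound 4 is therefore estimated at 10000 nM, within 5000 nM to 20000 nM.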

Compound 4, half-maximal inhibitory concentration: 10000 nM
The estimate for compound 4 equals the measured number at the digits printed; the range from low to high includes it.
By their numbers in this assay, from the lowest: compounds 1, 2, 3 and 4 (each within the scatter of the next).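

In this assay, within the data shown here, acetyl in place of methyl on an oxygen on an aromatic ring gave no change at the digits printed from compound 1 to compound 4 (within the scatter), the first reading at this oxygen, since the earlier steps all concerned the chain on the aromatic nitrogen. The change from methoxy to acetoxy brings in a carbonyl that compound 1 lacks, yet compound 4 gives 10000 nM, so the number is now unmoved by a change at this oxygen as well as by the changes on the chain. Nothing given here accounts for this result or links it to any measured property of the acetyl group.

From the compounds shown here alone, it remains open whether a hydroxyl, an amine or a longer acyl chain on this oxygen would separate from compound 1 in this assay, or whether any group here would do so. Going by these compounds, it is also open whether acetyl on this oxygen would read the same with cyano or (methoxycarbonyl)methyl on the chain on the aromatic nitrogen, as these groups appear here only with methoxy at this place.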